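Compound 3 to compound 4: losing the dimethylamino group

The compounds below may be only part of what the source reports. "The series", "measured", "known", "first", "only" and "open" are said of these compounds alone.

- Compound 1 `O=C(Nc1ccccc1)Nc1cccc(CNc2nccnc2Cl)c1`: 15600 nM
- Compound 2 `COc1ccccc1NC(=O)Nc1cccc(CNc2nccnc2Cl)c1`: 13700 nM
- Compound 3 `CN(C)c1ccc(NC(=O)Nc2cccc(CNc3nccnc3Cl)c2)cc1`: > 40000 nM (a limit of the assay, not a number)

All three values come from a functional assay on HepG2 cells (Homo sapiens) for antiproliferative activity, read by MTT assay, with a stated time of 48 h; on this read-out higher numbers stand for weaker inhibition and lower numbers for stronger inhibition. Compound 3 has no exact number, and its > 40000 nM is a limit.

Compound 4 `Cc1cccc(NC(=O)Nc2cccc(CNc3nccnc3Cl)c2)c1` differs from compound 3 in one place, with 3-methylphenyl in place of 4-(dimethylamino)phenyl on an amide-type nitrogen.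

Going by the values given here, two measured steps bear most directly on this change. Adding a dimethylamino group gave an at least 2.5-fold higher number from compound 1 to compound 3 (0.40 log units; beyond the scatter), and 4-(dimethylamino)phenyl in place of 2-methoxyphenyl gave an at least 2.9-fold higher number from compound 2 to compound 3 (0.46 log units; beyond the scatter). Both lie beyond the scatter. Methoxy in place of hydrogen on an aromatic carbon gave a 1.1-fold lower number from compound 1 to compound 2 (0.06 log units; within the scatter), which lies within the scatter.

Compound 4 has no dimethylamino group, so it is expected to fall close to compound 1 at 15600 nM and compound 2 at 13700 nM. Its methyl group has not been tested in this series, which leaves the range wide.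

In this assay the expected step is an at least 2.5-fold lower number from compound 3 to compound 4 (0.39 log units; beyond the scatter), towards stronger inhibition. For compound 4 the estimated value is 16000 nM, with an expected range from 7500 nM to 36000 nM.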

Compound 4, half-maximal inhibitory concentration: 11200 nM
Estimate against measurement, compound 4: 1.4-fold (0.15 log units) above, and the stated range covers the measured number.
By their numbers in this assay, from the lowest: compounds 4, 2 and 1 (each within the scatter of the next). At a limit, above all of these: compound 3.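

Putting 3-methylphenyl in place of 4-(dimethylamino)phenyl on the amide-type nitrogen gives an at least 3.5-fold lower number from compound 3 to compound 4 (0.55 log units; beyond the scatter) in this assay, and compound 3 enters this step only as a limit of the assay, not as a number: the limit of > 40000 nM in this assay, at which 1 of the 4 values shown sits.

Going by these compounds alone, compound 4 adds a second substituted phenyl group that stays level with the earlier compounds, with a 1.2-fold lower number from compound 2 to compound 4 (0.09 log units; within the scatter) and a 1.4-fold lower number from compound 1 to compound 4 (0.14 log units; within the scatter), so methyl joins methoxy among the changes that leave the number within the scatter. Of the four compounds shown, only compound 3, with its 4-(dimethylamino)phenyl, stands apart, while compounds 1, 2 and 4 cannot be told apart in this assay.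

Going by these compounds, the step from compound 3 to compound 4 changes both the group and its place on the ring, so it remains open whether 3-(dimethylamino)phenyl would track compound 3 or whether 4-methylphenyl would track compound 4. Also open is whether another group on this nitrogen, such as a carboxylic acid or a longer chain, would move the number beyond the scatter towards stronger inhibition, which no compound shown does relative to compound 1.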